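The source may report more compounds than this note shows. Statements on the series, on what has been measured and on what is new or still open speak of the compounds shown alone.

Compound 1 `O=[N+]([O-])C1=Cc2cc(C#Cc3ccc(C(F)(F)F)cc3)ccc2OC1C(F)(F)F`, compound 2 `O=[N+]([O-])C1=Cc2cc(C#Cc3ccc(F)cc3)ccc2OC1C(F)(F)F` and compound 3 `COC(=O)/C=C/c1ccc2c(c1)C=C([N+](=O)[O-])C(C(F)(F)F)O2` share one core. In an assay on 1321N1 cells for antagonist activity at P2Y purinoceptor 6 (Homo sapiens), read by FLIPR and calcium flux (a lower number here means a stronger inhibitor, a higher number a weaker inhibitor), compound 1 gives 5220 nM, compound 2 gives 8860 nM and compound 3 gives 2570 nM. Compound 2 thus stands at the highest of the three numbers: its step from compound 1 is a 1.7-fold higher number from compound 1 to compound 2 (0.23 log units; within the scatter), while compound 3 sits lower by a gap beyond the scatter. Compound 4 `O=[N+]([O-])C1=Cc2cc(C#Cc3ccc(O)cc3)ccc2OC1C(F)(F)F` differs from compound 2 by hydroxy in place of fluoro on an aromatic carbon. For the measured compounds named here, only the step of a 1.7-fold higher number from compound 1 to compound 2 (0.23 log units; within the scatter) bears on this change: it swapped one group for another on the same aromatic carbon, and the number barely moved. Going by the values given here, no measured step swaps fluoro for hydroxy anywhere, so nothing here shows whether adding a hydrogen-bond donor and acceptor at this place shifts the number. For compound 4 a step of a 1.3-fold lower number from compound 2 to compound 4 (0.10 log units; within the scatter) is therefore expected in this assay, with no change beyond the scatter. Compound 4 is estimated at 7000 nM, between 2500 nM and 20000 nM.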

Compound 4, half-maximal inhibitory concentration: 5360 nM
Beside the measured number, compound 4's estimate is 1.3-fold (0.12 log units) above it; the range from low to high includes it.
By their numbers in this assay, from the lowest: compound 3; then compounds 1, 4 and 2 (each within the scatter of the next).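

For the compounds shown here, with a 1.7-fold lower number from compound 2 to compound 4 (0.22 log units; within the scatter) in this assay, the change from 4-fluorophenyl to 4-hydroxyphenyl gives the first direct reading of a group with a hydrogen-bond donor and acceptor at this aromatic carbon, and the step stays within the scatter. Alongside a 1.0-fold higher number from compound 1 to compound 4 (0.01 log units; within the scatter) and the earlier trifluoromethyl to fluoro step, it means that trifluoromethyl, fluoro and hydroxy at this one place give numbers that cannot be told apart. No measurement shown here offers a reason for this sameness.

The compounds shown leave open whether an amine, a carboxylic acid or a longer chain at this place would also stay within the scatter. From the compounds shown here alone, whether a hydroxy group on another carbon of the same ring would read the same also remains open.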